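A few compounds are considered here, and "the series" means these few. Any claim that something is new, unique, unknown or untested is made for them only; others in the source may bear on it.

In a functional assay on NB-4 cells (Homo sapiens) for cytotoxicity, read by CCK-8 assay, with a stated time of 24 h (a lower number here means a stronger inhibitor, a higher number a weaker inhibitor), compound 1 `C=CC(=O)N1C(=O)CC(c2ccc(C)cc2)Sc2ccccc21`, which carries methyl on an aromatic carbon, gives 37300 nM. Compound 2 `C=CC(=O)N1C(=O)CC(c2ccccc2)Sc2ccccc21`, with hydrogen in that place, gives 35500 nM, and compound 3 `C=CC(=O)N1C(=O)CC(c2ccc(C(=O)OC)cc2)Sc2ccccc21`, with methoxycarbonyl there, gives 24400 nM. Compound 3 therefore stands within the usual scatter of both other compounds, and the three numbers cannot be ranked.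

The next compound is compound 4 `C=CC(=O)N1C(=O)CC(c2ccc(C#N)cc2)Sc2ccccc21`, with cyano in place of methoxycarbonyl on an aromatic carbon.

Going by the values given here, three measured steps bear on this change, since each swaps the group at this same place: a 1.1-fold lower number from compound 1 to compound 2 (0.02 log units; within the scatter), a 1.5-fold lower number from compound 1 to compound 3 (0.18 log units; within the scatter) and a 1.5-fold lower number from compound 2 to compound 3 (0.16 log units; within the scatter). Among the compounds with values here, none of them lies beyond the scatter, although no measured compound carries cyano. On that evidence, no step beyond the scatter is expected in this assay, and the estimated change is a 1.1-fold higher number from compound 3 to compound 4 (0.06 log units; within the scatter). Compound 4 is expected at 28000 nM, within an estimated range of 14000 nM to 50000 nM.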

Compound 4, half-maximal inhibitory concentration: 62400 nM
Compound 4: the middle estimate sits 2.2-fold (0.35 log units) below what was measured; measured number outside the range, above it.
By their numbers in this assay, from the lowest: compounds 3, 2, 1 and 4 (each within the scatter of the next, the first and the last beyond it).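

In this assay this position gives its first step beyond the scatter: putting cyano in place of methoxycarbonyl, on an aromatic carbon para to a large group, gives a 2.6-fold higher number from compound 3 to compound 4 (0.41 log units; beyond the scatter) in a modest shift. The same cyano stays within the scatter of the simpler groups, with a 1.8-fold higher number from compound 2 to compound 4 (0.24 log units; within the scatter) against hydrogen and a 1.7-fold higher number from compound 1 to compound 4 (0.22 log units; within the scatter) against methyl, so only compound 3 and compound 4 can be told apart among the four. Nothing measured here accounts for the gap between these two groups.

The compounds shown leave open whether an amine, a carboxylic acid or a longer chain at this place would move the number further in either direction. They also leave open whether changes elsewhere on the shared core would matter more than this one.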